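Removing the Lactam Side Group from Compound 1

The source may report more compounds than this note shows. Statements on the series, on what has been measured and on what is new or still open speak of the compounds shown alone.

In an ADME assay on a cell-free system (plasma, Homo sapiens) for protein binding, at pH 7.4, compound 1 (`CCN1CC(c2nc(C(=O)NCc3ccc(F)cc3)c(O)c3ncccc23)CC1=O`) gives 98.9%, while compound 2 (`CCN1CC(c2nc(C(=O)NCc3ccc(F)cc3S(C)(=O)=O)c(O)c3ncccc23)CC1=O`) gives 96%. Of these two compounds, compound 1 therefore has the lower unbound fraction. Compound 3 (`O=C(NCc1ccc(F)cc1)c1ncc2cccnc2c1O`) has not yet been measured. It carries hydrogen in place of 1-ethyl-5-oxopyrrolidin-3-yl on an aromatic carbon, and the change from compound 1 is hydrogen in place of 1-ethyl-5-oxopyrrolidin-3-yl on an aromatic carbon.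

Going by the values given here, only one measured step is available for comparison: a 3.6-fold higher unbound fraction from compound 1 to compound 2 (0.56 log units; beyond the scatter). That modest step came from methylsulfonyl in place of hydrogen on an aromatic carbon, not from any change to the 1-ethyl-5-oxopyrrolidin-3-yl group, so it bears on the present change only indirectly. The data hold no measured removal of this group, which leaves both size and direction uncertain. Compound 1 with 98.9% already lies close to full binding, so a small shift toward more free compound seems the likelier outcome, though not one clearly beyond the scatter. The expected change is a 1.8-fold higher unbound fraction from compound 1 to compound 3 (0.26 log units; within the scatter). For compound 3 the estimated value is 98%, with an expected range from 94% to 99.5%.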

Compound 3, plasma protein binding: 99.2%
For compound 3 the middle estimate is 2.5-fold (0.40 log units) (unbound fraction) above the measured one; the range from low to high includes it.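

At this position, on an aromatic carbon next to the ring nitrogen and para to a hydroxy group, hydrogen in place of the 1-ethyl-5-oxopyrrolidin-3-yl group gives a 1.4-fold lower unbound fraction from compound 1 to compound 3 (0.14 log units; within the scatter) in this assay, so the whole group, with its five-membered non-aromatic ring, can be lost without a difference that this read-out separates from the scatter. Of the two steps that start from compound 1, only the methylsulfonyl change, a 3.6-fold higher unbound fraction from compound 1 to compound 2 (0.56 log units; beyond the scatter), lies beyond the scatter, so among these compounds it is the only one of the two changes shown to alter binding to plasma protein. Nothing in hand gives a reason for the result at this position.

On these data alone, what remains open is whether this position tolerates any substituent in the same way, or whether a group of a different kind there, such as an amine or a carboxylic acid, would free more of the compound in this assay. As far as these compounds go, it is also open whether methylsulfonyl on the fluorinated aromatic ring would give a similar step when the 1-ethyl-5-oxopyrrolidin-3-yl group is absent, as in compound 3.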